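This account rests on a few compounds, and the source may have more. Where it says the series, first, only, none or still open, it means among the compounds named here.

Compound 1 `CC(C)N(Cc1cccc(OCCCCCC(=O)O)c1)C(=O)c1ccc(-c2ccncc2)cc1` is known in an ADME assay on Raji cells (Homo sapiens) for cytotoxicity, read by CellTiter-Glo and resazurin assay, with a stated time of 72 h (a lower number here means that less compound is needed, a higher number that more compound is needed for the effect), only through a limit: compound 1 gives > 26000 nM. Compound 2 `COc1cccc(-c2ccc(C(=O)N(Cc3cccc(OCCCCCC(=O)O)c3)C(C)C)cc2)c1` likewise reaches only a limit, giving > 20900 nM. Going by the values given here, the single measured step, a step that the two limits leave unreadable from compound 1 to compound 2, offers no readable size, as the limit of > 20900 nM in this assay, at which 1 of the 2 values shown sits, and the limit of > 26000 nM in this assay, at which 1 of the 2 values shown sits, show. Compound 3 `CC(C)N(Cc1cccc(OCCCCCC(=O)O)c1)C(=O)c1ccc(-c2cccc(OC(F)(F)F)c2)cc1` carries 3-(trifluoromethoxy)phenyl in place of pyridin-4-yl on an aromatic carbon. Among the compounds with values here, no measured step speaks to this change, so no shift beyond the scatter is expected. Compound 3 is therefore expected to remain at a limit, estimated near 26000 nM, between 10000 nM and 60000 nM. The expected step of a number no higher from compound 1 to compound 3 (the limit leaves the size open) is thus essentially flat.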

Compound 3, half-maximal effective concentration: > 26000 nM
Compound 3 ended at the assay's limit (the forecaster's own chance of this, stated with the estimate: 80%); the middle value sits exactly at the limit.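

Compound 1, compound 2 and compound 3 all stand only at limits in this assay, so the steps among them cannot be read. The compounds shown leave open whether any replacement of pyridin-4-yl changes the effect at all.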